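Methoxy for trifluoromethyl: the expected unbound share of compound 4

This account rests on a few compounds, and the source may have more. Where it says the series, first, only, none or still open, it means among the compounds named here.

In an ADME assay on brain (Rattus norvegicus) for protein binding (a higher number here means a larger unbound share of the compound, a lower number a smaller unbound share), compound 1 (`Cc1c(Cl)nnc2sc(C(=O)NC3CN(c4cc(C(F)(F)F)ncc4Cl)C3)c(N)c12`) gives 0.01 as the lowest of three numbers. Compound 2 (`COc1nnc2sc(C(=O)NC3CN(c4ncc(C(F)(F)F)cn4)C3)c(N)c2c1C`) stands at 0.039 and compound 3 (`Cc1nnc2sc(C(=O)NC3CN(c4ncc(C(F)(F)F)cn4)C3)c(N)c2c1C`) at 0.41 on the same read-out. Compound 4 (`COc1cc(N2CC(NC(=O)c3sc4nnc(Cl)c(C)c4c3N)C2)c(Cl)cn1`) keeps the core of compound 1 but carries methoxy in place of trifluoromethyl on an aromatic carbon. Among the compounds with values here, no measured step makes this exchange. The only one involving methoxy is an 11-fold higher number from compound 2 to compound 3 (1.02 log units; beyond the scatter) for methyl in place of methoxy, a large step at another place in the structure. It therefore sets no size here, and only a small upward change is expected (a 1.8-fold higher number from compound 1 to compound 4 (0.26 log units; within the scatter)). Compound 4 is estimated at 0.018 (range 0.008 to 0.04).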

Compound 4, unbound fraction: 0.01
Compound 4: the middle estimate sits 1.8-fold (0.26 log units) above what was measured; measured number inside the range.
By their numbers in this assay, from the lowest: compounds 1 and 4 (each within the scatter of the next); then compound 2; then compound 3.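

In this assay, methoxy in place of trifluoromethyl, next to the ring nitrogen and para to a chloro group, gives no change at the digits printed from compound 1 to compound 4 (within the scatter). At this position, then, the exchange leaves the unbound share within the scatter, unlike the large step at another place in the structure, where methyl replaces methoxy, an 11-fold higher number from compound 2 to compound 3 (1.02 log units; beyond the scatter). Nothing shown accounts for this difference between the two places. Going by these compounds, whether an amine or a carboxylic acid at this position would shift the unbound share stays open. So does whether this exchange would give the same result on another compound.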